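The source may hold more compounds than are shown below. What is called first, only, known or untested is meant among the compounds shown, and "the series" means these compounds.

Working notes on the series. In a functional assay on Gurav cells (Homo sapiens) for inhibition, read by sulforhodamine B assay (a higher number here means a weaker inhibitor of growth, a lower number a stronger inhibitor of growth), compound 1 (`Cc1ccc2[nH]c(-c3ccc(-c4ccc(-c5cccc(Cl)c5)cc4)cc3)nc2c1`) gives 2120 nM, and compound 2 (`Cc1ccc2[nH]c(-c3ccc(-c4ccc(-c5ccc(C(F)(F)F)cc5)cc4)cc3)nc2c1`) gives 12000 nM. Compound 2 therefore holds the higher of the two numbers, making it the weaker growth inhibitor of this pair.

The next compound is compound 3 (`Cc1ccc2[nH]c(-c3ccc(-c4ccc(-c5ccc(OC(F)(F)F)cc5)cc4)cc3)nc2c1`), which has trifluoromethoxy in place of trifluoromethyl on an aromatic carbon, para to a large group: trifluoromethoxy in place of trifluoromethyl on an aromatic carbon.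

Among the compounds with values here, only one measured step bears on this change: a 5.7-fold higher number from compound 1 to compound 2 (0.75 log units; beyond the scatter). That step replaces 3-chlorophenyl with 4-(trifluoromethyl)phenyl, so it shows that a change of this outer aryl group can move the number in this assay beyond the scatter. Within the data shown here, it is only an indirect guide, as no measured pair exchanges trifluoromethyl for trifluoromethoxy. The change to compound 3 is a smaller edit than that step, so a smaller shift is expected, with no firm direction. The expected step is a 1.2-fold lower number from compound 2 to compound 3 (0.08 log units; within the scatter), which would lie within the scatter. For compound 3, the estimate is 10000 nM, with an expected range of 4000 nM to 25000 nM.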

Compound 3, concentration for 50% growth inhibition: 11000 nM
Compound 3: middle estimate off by 1.1-fold (0.04 log units), on the low side, and the stated range covers the measured number.
By their numbers in this assay, from the lowest: compound 1; then compounds 3 and 2 (each within the scatter of the next).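

In this assay, the exchange of trifluoromethyl for trifluoromethoxy on an aromatic carbon, para to a large group, gives a 1.1-fold lower number from compound 2 to compound 3 (0.04 log units; within the scatter) and so stays within the scatter; the earlier pair could not show that the oxygen entering here leaves the number in place. The distance from the 3-chlorophenyl compound persists with the new group, with a 5.2-fold higher number from compound 1 to compound 3 (0.72 log units; beyond the scatter) beyond the scatter, so compound 2 and compound 3 both stand apart from compound 1 by a similar margin. No measurement at hand gives a reason for either step.

Compound 1 differs from compound 2 and compound 3 in both the substituent and where it sits on the outer ring, so a 4-chlorophenyl or a 3-(trifluoromethyl)phenyl group would be needed to separate those two changes. The compounds shown carry only chloro, trifluoromethyl and trifluoromethoxy on this ring, which leaves open how an amine or a carboxylic acid at the same place would read.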